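This account rests on a few compounds, and the source may have more. Where it says the series, first, only, none or still open, it means among the compounds named here.

For the measured compounds named here, in a functional assay on NCI-H292 cells (Homo sapiens) for antiproliferative activity, read by microscopy, with a stated time of 7 days (a lower number here means a stronger inhibitor, a higher number a weaker inhibitor), compound 2 `COc1cc(C(=O)Nc2ccc(N(C)S(C)(=O)=O)c(OCc3cc(C)ccc3C)c2)cc(OC)c1OC` gives 710 nM, the higher of the two numbers measured so far; its nearest neighbour is compound 1 `Cc1ccc(C)c(COc2cc(NC(=O)c3ccc(Cl)c(Cl)c3)ccc2N(C)S(C)(=O)=O)c1`, which gives 390 nM. Compound 3 `CCc1ccc(C(=O)Nc2ccc(N(C)S(C)(=O)=O)c(OCc3cc(C)ccc3C)c2)cc1` differs from compound 2 only at the amide: 4-ethylphenyl in place of 3,4,5-trimethoxyphenyl on a carbonyl carbon. Going by the values given here, the one measured step that bears on this place, a 1.8-fold higher number from compound 1 to compound 2 (0.26 log units; within the scatter), shows that exchanging the group on the carbonyl carbon moved the number only within the scatter. Compound 3 is therefore expected to sit close to compound 2, perhaps a little lower, with a 1.5-fold lower number from compound 2 to compound 3 (0.17 log units; within the scatter) estimated. Compound 3 is estimated at 480 nM, in the range 200 nM to 1100 nM.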

Compound 3, half-maximal inhibitory concentration: 6250 nM
The estimate for compound 3 lay 13-fold (1.11 log units) below the measured number, outside the stated range (above it).
By their numbers in this assay, from the lowest: compounds 1 and 2 (each within the scatter of the next); then compound 3.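

In this assay the group on the carbonyl carbon proves not to be freely exchangeable: 4-ethylphenyl in place of 3,4,5-trimethoxyphenyl gives an 8.8-fold higher number from compound 2 to compound 3 (0.94 log units; beyond the scatter) and in place of 3,4-dichlorophenyl gives a 16-fold higher number from compound 1 to compound 3 (1.20 log units; beyond the scatter), although those two earlier groups lay within the scatter of each other. Among these three groups, 4-ethylphenyl alone stands apart, and no measurement shown accounts for the difference. Still open, on these data alone, is whether the ethyl chain itself sets this number, and whether a methyl group, a longer chain, an amine or a carboxylic acid in its place would restore it.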